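Capping the Remaining Hydroxy Group with Methyl

The source may report more compounds than this note shows. Statements on the series, on what has been measured and on what is new or still open speak of the compounds shown alone.

Compound 1 `COc1cc(C(c2cc(OC)c(OC)c(OC)c2)[C@@H]2COC(=O)[C@H]2C)cc(OC)c1O` and compound 2 `COc1cc(C(c2cc(OC)c(OC)c(OC)c2)[C@@H]2COC(=O)[C@H]2C)cc(O)c1OC` share one core and differ only in where the hydroxy and methoxy groups sit on the aromatic ring. In an ADME assay on WI-38 cells (Homo sapiens) for cytotoxicity (a higher number here means a weaker inhibitor, a lower number a stronger inhibitor), compound 1 gives 184000 nM. Compound 2 reaches only the limit of this assay, > 231000 nM, so no number is known for it. Compound 2 thus stands at the limit of > 231000 nM in this assay, at which 1 of the 2 values shown sits, the weak end of what has been measured so far. Compound 3 `COc1cc(C(c2cc(OC)c(OC)c(OC)c2)[C@@H]2COC(=O)[C@H]2C)cc(OC)c1OC` carries the change (methyl in place of hydrogen on an oxygen on an aromatic ring), the hydroxy becoming a methoxy. Among the measured compounds shown here, no step between measured compounds is available, so only the two values of compound 1 and compound 2 frame the expectation, and both lie far toward weak inhibition in this assay. The step is expected to be none beyond the scatter, an at least 1.0-fold lower number from compound 2 to compound 3 (0.02 log units; that floor lies within the scatter), in this assay. Compound 3 is therefore estimated at 220000 nM, within a range of 120000 nM to 400000 nM, with a fair chance that this assay again reports only a limit.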

Compound 3, half-maximal inhibitory concentration: 175000 nM
Compound 3: the middle estimate sits 1.3-fold (0.10 log units) above what was measured; measured number inside the range.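

In this assay, the methyl cap on the oxygen now has a reading from the hydroxy compound with a number: the change gives a 1.1-fold lower number from compound 1 to compound 3 (0.02 log units; within the scatter), so at this position it leaves the value within the scatter. Read from the other hydroxy compound, the same change gives an at least 1.3-fold lower number from compound 2 to compound 3 (0.12 log units; that floor lies within the scatter), which adds no step beyond the scatter. The value of compound 2 remains a limit and not a number: the limit of > 231000 nM in this assay, at which 1 of the 3 values shown sits.

The compounds shown leave open whether a longer chain on this oxygen, such as ethyl, or a carboxylic acid or an amine in place of the methoxy, would move the number beyond the scatter. They also leave open how the methoxy groups on the other aromatic ring bear on this value.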